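Swapping the Benzyl Substituent on a Nucleoside Core

This account rests on a few compounds, and the source may have more. Where it says the series, first, only, none or still open, it means among the compounds named here.

Measured compounds:
- compound 1, `COc1cccc(CNc2ncnc3c2ncn3[C@@H]2O[C@H](CO)[C@@H](O)[C@H]2O)c1`: 4900 nM
- compound 2, `OC[C@H]1O[C@@H](n2cnc3c(NCc4cc(F)cc(F)c4)ncnc32)C(O)C1O`: 9100 nM

Both compounds were tested in a functional assay on HL-60 cells (Homo sapiens) for antiproliferative activity, with a stated time of 72 h; on this read-out lower numbers stand for stronger inhibition and higher numbers for weaker inhibition. Compound 1 gives the lower of the two numbers, but the gap to compound 2 lies within the usual scatter, so the two cannot be told apart on this read-out. Compound 3, `Cc1ccc(O)c(CNc2ncnc3c2ncn3[C@@H]2O[C@H](CO)[C@@H](O)[C@H]2O)c1`, has not yet been measured. It keeps the shared core of compound 1 and differs only in the group on the saturated chain carbon bound to a nitrogen on the aromatic ring: 2-hydroxy-5-methylphenyl in place of 3-methoxyphenyl on a saturated chain carbon bound to a nitrogen on an aromatic ring. Among the compounds with values here, no step between measured compounds covers this kind of change, so nothing here shows its direction. The expectation is therefore a step of a 1.0-fold higher number from compound 1 to compound 3 (0.01 log units; within the scatter), none beyond the scatter. In this assay, compound 3 is estimated at 5000 nM, with a range from 1500 nM to 16000 nM.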

Compound 3, half-maximal inhibitory concentration: 15000 nM
For compound 3 the middle estimate is 3.0-fold (0.48 log units) below the measured one; the measured number falls inside the stated range.
By their numbers in this assay, from the lowest: compounds 1, 2 and 3 (each within the scatter of the next, the first and the last beyond it).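

The benzyl position on the shared core does respond to this exchange: in this assay, 2-hydroxy-5-methylbenzyl in place of 3-methoxybenzyl gives a 3.1-fold higher number from compound 1 to compound 3 (0.49 log units; beyond the scatter). The two groups are made of the same atoms, joined differently, and the entering group has a hydrogen-bond donor that the leaving group lacks, so rearranging those atoms is enough to move the number beyond the scatter. Nothing measured here explains why the number rises.

This single step changes the hydroxy, methyl and methoxy features together, so it remains open which of them accounts for the higher number. On these data alone, it is also open how the shared core would fare with a plain benzyl group, or with an amine or a carboxylic acid on the benzyl ring.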